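Methyl in place of fluoro on the pendant ring

This account rests on a few compounds, and the source may have more. Where it says the series, first, only, none or still open, it means among the compounds named here.

Compound 1, `CCn1nc(C)c2c1CCN(C(C(=O)NC)c1ccccc1)C2CCc1ccc(Cl)cc1`, gives 993 nM in a functional assay on CHO cells for antagonist activity at Orexin/Hypocretin receptor type 1 (Homo sapiens), read by FLIPR and calcium flux; on this read-out lower numbers stand for stronger inhibition and higher numbers for weaker inhibition. Compound 2, `CCn1nc(C)c2c1CCN(C(C(=O)NC)c1ccccc1)C2CCc1cccc(C(F)(F)F)c1`, gives 358 nM. Compound 3, `CCn1nc(C)c2c1CCN(C(C(=O)NC)c1ccccc1)C2CCc1cccc(F)c1`, gives 402 nM.

Compound 3 holds the second highest of the three numbers. Its nearest neighbour is compound 2, with a 1.1-fold higher number from compound 2 to compound 3 (0.05 log units; within the scatter), a gap within the scatter. Its furthest is compound 1, with a 2.5-fold lower number from compound 1 to compound 3 (0.39 log units; beyond the scatter).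

Compound 4, `CCn1nc(C)c2c1CCN(C(C(=O)NC)c1ccccc1)C2CCc1cccc(C)c1`, is not yet measured. It differs from compound 3 in one place: methyl in place of fluoro on an aromatic carbon. Two kinds of measured step bear on this. The step of a 1.1-fold higher number from compound 2 to compound 3 (0.05 log units; within the scatter) shows that swapping one small group for another at this same place left the number essentially unchanged. The steps of a 2.8-fold lower number from compound 1 to compound 2 (0.44 log units; beyond the scatter) and a 2.5-fold lower number from compound 1 to compound 3 (0.39 log units; beyond the scatter) show modest gains when the substituent was moved from the 4-chlorophenyl pattern to a 3-substituted ring, but they do not involve a methyl. For the measured compounds named here, no measured step exchanges a halogen for a methyl, so the expectation rests mainly on the first of these, and no step beyond the scatter is expected: a 1.0-fold higher number from compound 3 to compound 4 (0.02 log units; within the scatter). Compound 4 is therefore estimated at 420 nM, with a range of 200 nM to 900 nM.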

Compound 4, half-maximal inhibitory concentration: 180 nM
Compound 4: middle estimate off by 2.3-fold (0.37 log units), on the high side; the measured number lies below the stated range.
By their numbers in this assay, from the lowest: compounds 4, 2 and 3 (each within the scatter of the next, the first and the last beyond it); then compound 1.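

Swapping one small group for another at this place on the ring can matter in this assay: replacing fluoro with methyl gives a step beyond the scatter (a 2.2-fold lower number from compound 3 to compound 4 (0.35 log units; beyond the scatter)), whereas the earlier swap of trifluoromethyl for fluoro did not. Methyl and trifluoromethyl, however, remain within the scatter of each other (a 2.0-fold lower number from compound 2 to compound 4 (0.30 log units; within the scatter)), so the result separates methyl from fluoro but not from trifluoromethyl. The 3-methylphenyl group also opens the widest gap so far from the 4-chlorophenyl compound (a 5.5-fold lower number from compound 1 to compound 4 (0.74 log units; beyond the scatter)), and no measurement offered here explains these differences.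

Because the 4-chlorophenyl and 3-methylphenyl groups differ in both substituent and substitution pattern, that gap cannot be assigned to either change alone. As far as these compounds go, whether an ethyl, a methoxy or an amine at this place would behave like methyl also remains open.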